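This account rests on a few compounds, and the source may have more. Where it says the series, first, only, none or still open, it means among the compounds named here.

Compounds measured so far:
- compound 1, `C#CCNC1CCc2c(SCCc3cccc(Br)c3)cccc21`, gives 30500 nM
- compound 2, `C#CCNC1CCc2c(SCCc3cccc(Cl)c3)cccc21`, gives 82400 nM
- compound 3, `C#CCNC1CCc2c(SCCc3ccc(Cl)c(Cl)c3)cccc21`, gives 3850 nM

All three were tested in an assay on isolated protein for inhibition of Amine oxidase [flavin-containing] B (Homo sapiens); on this read-out lower numbers stand for stronger inhibition and higher numbers for weaker inhibition. Among them compound 3 stands lowest, with compound 1 the nearest and compound 2 the furthest away. The step of a 21-fold lower number from compound 2 to compound 3 (1.33 log units; beyond the scatter) was the largest seen, and the step of a 2.7-fold higher number from compound 1 to compound 2 (0.43 log units; beyond the scatter) a smaller one. Compound 4, `C#CCNC1CCc2c(SCCc3ccc(C)cc3)cccc21`, has not been measured yet. It differs from compound 3 in one place: 4-methylphenyl in place of 3,4-dichlorophenyl on a saturated chain carbon, two bonds along the chain from a sulfur. The step from compound 2 to compound 3 bears on this change most directly, since it shows what adding one chloro did; compound 4 gives up both chlorines and gains a methyl instead. For the measured compounds named here, no measured pair shows a methyl group, so the expectation is a weakening of unknown size. For compound 4 a step of a 10-fold higher number from compound 3 to compound 4 (1.02 log units; beyond the scatter) is expected. Compound 4 is therefore estimated at 40000 nM, within a range of 10000 nM to 150000 nM.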

Compound 4, half-maximal inhibitory concentration: 25800 nM
Compound 4: the middle estimate sits 1.6-fold (0.19 log units) above what was measured; the measured number falls inside the stated range.
By their numbers in this assay, from the lowest: compound 3; then compounds 4 and 1 (each within the scatter of the next); then compound 2.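

For the compounds shown here, compound 4 is the first compound here with no halogen on the phenyl group at this place, and in this assay trading 3,4-dichlorophenyl for 4-methylphenyl gives a 6.7-fold higher number from compound 3 to compound 4 (0.83 log units; beyond the scatter). A halogen is still not required to reach this range: against 3-chlorophenyl, the same group gives a 3.2-fold lower number from compound 2 to compound 4 (0.50 log units; beyond the scatter), while against 3-bromophenyl it gives a 1.2-fold lower number from compound 1 to compound 4 (0.07 log units; within the scatter), so those two cannot be told apart. Among the four groups, 3,4-dichlorophenyl alone stands clear of all the others on the low side.

Nothing available explains why the numbers move in this way. Also open is how 4-chlorophenyl or 3,4-dimethylphenyl would read here, since the compounds shown change the kind of group and its place on the ring together.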